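From a Long Nitrile Chain to a Plain Butyl Ether

The compounds below may be only part of what the source reports. "The series", "measured", "known", "first", "only" and "open" are said of these compounds alone.

Measured in an assay on isolated protein for binding affinity to leukotriene B4 receptor 1 (Homo sapiens), tested at 1 uM; a higher number here means more inhibition at the concentration tested (going by the name of the read-out), a lower number less inhibition:
compound 1, `C=CCc1cc(C(C)=O)c(O)cc1OCC#N`: 2%
compound 2, `C=CCc1cc(C(C)=O)c(O)cc1OCCCCCC#N`: 41%
compound 3, `C=CCc1cc(C(C)=O)c(O)cc1OCCCCCCCCC#N`: 50%

Compound 3 gives the highest of the three numbers in this assay, but its gap to compound 2 is within the scatter, so the two cannot be ordered; only compound 1 stands clearly lower. Compound 4, `C=CCc1cc(C(C)=O)c(O)cc1OCCCC`, differs from compound 3 by hydrogen in place of 4-cyanobutyl on a saturated chain carbon, four bonds along the chain from an oxygen on an aromatic ring. Going by the values given here, two measured steps bear on this. Lengthening the chain gave a number 39 percentage points higher from compound 1 to compound 2 (beyond the scatter), a large rise, whereas the further lengthening gave a number 9 percentage points higher from compound 2 to compound 3 (within the scatter). Compound 4 shortens the chain well below that of compound 2 and loses the nitrile, so a fall is expected. For compound 4 the expected step is a number 32 percentage points lower from compound 3 to compound 4 (beyond the scatter), giving an estimate of 18%, within 3% to 38%.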

Compound 4, a percentage reported as inhibition, at one concentration (the size of the read-out at that concentration, not a potency): 8%
Compound 4: middle estimate off by 10 percentage points, on the high side, within the range that was stated.
By their numbers in this assay, from the lowest: compounds 1 and 4 (each within the scatter of the next); then compounds 2 and 3 (each within the scatter of the next).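

In this assay, the plain butyl ether does not keep the numbers of the long nitrile chains: the step is large against both compound 3 (the change reads a number 42 percentage points lower from compound 3 to compound 4 (beyond the scatter) in that case) and compound 2 (here a number 33 percentage points lower from compound 2 to compound 4 (beyond the scatter) at the same place). Compound 4 instead stands level with the shortest nitrile chain (the change reads a number 6 percentage points higher from compound 1 to compound 4 (within the scatter) here), so those two cannot be ordered. No measurement shown gives a reason for these steps.

Chain length and the nitrile remain tied together here. A longer plain alkyl chain, or a carboxylic acid or an amine at the chain end, would be needed to separate them.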